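This account rests on a few compounds, and the source may have more. Where it says the series, first, only, none or still open, it means among the compounds named here.

The measured compounds, in an assay on Huh-7 cells for agonist activity at Bile acid receptor (Homo sapiens), read by a luciferase reporter; a higher number here means that more compound is needed for the effect, a lower number that less compound is needed:
compound 1, `CCn1c(-c2ccc(OCc3c(-c4c(Cl)cccc4Cl)noc3C(C)C)cc2)nc2ccc(C(=O)O)cc21`, 2.31 nM
compound 2, `CCCn1c(-c2ccc(OCc3c(-c4c(Cl)cccc4Cl)noc3C(C)C)cc2)nc2ccc(C(=O)O)cc21`, 9.3 nM
compound 3, `CC(C)c1onc(-c2c(Cl)cccc2Cl)c1COc1ccc(-c2nc3ccc(C(=O)O)cc3n2C2CCCCCC2)cc1`, 14.8 nM

Compound 3 gives the highest of the three numbers in this assay, but its value and that of compound 2 lie within the scatter of each other, so only compound 1 stands clearly apart from it. Compound 4, `CC(=O)C1CCC(Cn2c(-c3ccc(OCc4c(-c5c(Cl)cccc5Cl)noc4C(C)C)cc3)nc3ccc(C(=O)O)cc32)CC1`, differs from compound 3 by (4-acetylcyclohexyl)methyl in place of cycloheptyl on an aromatic nitrogen. Among the compounds with values here, two measured steps bear on this position: a 4.0-fold higher number from compound 1 to compound 2 (0.60 log units; beyond the scatter) and a 6.4-fold higher number from compound 1 to compound 3 (0.81 log units; beyond the scatter), while a 1.6-fold higher number from compound 2 to compound 3 (0.20 log units; within the scatter). Within the data shown here, both steps beyond the scatter run toward higher numbers as the group on that nitrogen gains heavy atoms, and the group entering compound 4 brings more heavy atoms again, though no measured pair shows a carbonyl in this part of the structure. On that basis a further modest rise for compound 4 is expected, estimated as a 1.7-fold higher number from compound 3 to compound 4 (0.23 log units; within the scatter). The estimate for compound 4 in this assay is therefore 25 nM, with a range from 6 nM to 100 nM.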

Compound 4, half-maximal effective concentration: 1170 nM
Compound 4: the middle estimate sits 47-fold (1.67 log units) below what was measured; the whole stated range lies below it.
By their numbers in this assay, from the lowest: compound 1; then compounds 2 and 3 (each within the scatter of the next); then compound 4.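

Within the data shown here, at this aromatic nitrogen the earlier steps were modest, whereas the step to compound 4 is large in this assay: a 79-fold higher number from compound 3 to compound 4 (1.90 log units; beyond the scatter), with a 130-fold higher number from compound 2 to compound 4 (2.10 log units; beyond the scatter) and a 510-fold higher number from compound 1 to compound 4 (2.70 log units; beyond the scatter). The position therefore does not merely give a gradual rise as the group grows, since the change from cycloheptyl to (4-acetylcyclohexyl)methyl costs far more than any earlier change there. That change alters the ring and brings in a hydrogen-bond acceptor together, and nothing available accounts for the size of the step.

The compounds shown leave open whether the rise goes with the acetyl group or with the cyclohexylmethyl frame that carries it. A plain cyclohexylmethyl group on that nitrogen would separate the two, and a hydroxyl, an amine or a carboxylic acid in place of the acetyl would show how much depends on that end of the group.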